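The source may hold more compounds than are shown below. What is called first, only, known or untested is meant among the compounds shown, and "the series" means these compounds.

Compound 1 `COc1cc2c(Oc3ccc(NC(=O)c4cc(-c5ccccc5)ccn4)cc3F)ccnc2cc1OCCCN1CCN(C)CC1` is tested in a functional assay on MKN-45 cells (Homo sapiens) for cytotoxicity, read by MTT assay, with a stated time of 72 h (on this read-out lower numbers stand for stronger inhibition and higher numbers for weaker inhibition), and gives 150 nM. Compound 2 `COc1ccc(-c2ccnc(C(=O)Nc3ccc(Oc4ccnc5cc(OCCCN6CCN(C)CC6)c(OC)cc45)c(F)c3)c2)cc1` carries methoxy in place of hydrogen on an aromatic carbon; in this assay compound 2 gives 250 nM, and the step is a 1.7-fold higher number from compound 1 to compound 2 (0.22 log units; within the scatter). Compound 3 `COc1ccc(-c2ccnc(C(=O)Nc3ccc(Oc4ccnc5cc(OCCCN6CCCC6)c(OC)cc45)c(F)c3)c2)cc1` differs from compound 1 in more than one place, and how the two cores differ is not broken down here. In this assay compound 3 gives 150 nM; the step is a 1.7-fold lower number from compound 2 to compound 3 (0.22 log units; within the scatter). Compound 4 `COc1ccc(-c2ccnc(C(=O)Nc3ccc(Oc4ccnc5cc(OCCCN6CCCC6)c(OC)cc45)c(F)c3)c2)c(OC)c1` has not yet been measured; it carries methoxy in place of hydrogen on an aromatic carbon. Among the measured compounds shown here, this is the same kind of change as the one made from compound 1 to compound 2, though not the same: there the methoxy entered para to a large group, here it enters ortho to a large group and meta to a methoxy group. Because the earlier step of a 1.7-fold higher number from compound 1 to compound 2 (0.22 log units; within the scatter) stayed within the scatter, the expected step is a 1.5-fold higher number from compound 3 to compound 4 (0.19 log units; within the scatter). Compound 4 is estimated at 230 nM.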

Compound 4, half-maximal inhibitory concentration: 740 nM
Estimate against measurement, compound 4: 3.2-fold (0.51 log units) below; the measured number lies above the stated range.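

In this assay, turning the 4-methoxyphenyl of compound 3 into the 2,4-dimethoxyphenyl of compound 4 gives a 4.9-fold higher number from compound 3 to compound 4 (0.69 log units; beyond the scatter). Set beside the earlier step, the same kind of change does not have the same size on both cores: the same change on two cores in this assay, a 1.7-fold higher number (0.22 log units; within the scatter) from compound 1 to compound 2 and a 4.9-fold higher number (0.69 log units; beyond the scatter) from compound 3 to compound 4, 3.0-fold (0.47 log units) apart, beyond the scatter of two such steps. Among the compounds shown here, this does not show why, since there are only two pairs, they differ in the ring amine and in the ring's other substituents, and the new methoxy sits ortho to a large group and meta to a methoxy group.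

Still open, from the compounds shown here alone, is whether 2,4-dimethoxyphenyl would give a similar step with the 4-methylpiperazin-1-yl chain of compound 2. Also open, going by these compounds, is whether a fluorine or an ethoxy in that same place would behave like the methoxy.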